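The source may hold more compounds than are shown below. What is called first, only, known or untested is meant among the compounds shown, and "the series" means these compounds.

Compound 1 `O=C(CCN1C(=O)CSc2ccccc21)N1CCN(c2ccc([N+](=O)[O-])cc2)CC1`: 68100 nM
Compound 2 `CC(C)(C)OC(=O)N1CCN(C(=O)CCN2C(=O)CSc3ccccc32)CC1`: 51500 nM
Compound 3 `O=C(CCN1C(=O)CSc2ccccc21)N1CCN(c2ccc(F)cc2)CC1`: > 100000 nM (a limit of the assay, not a number)

In a functional assay (MiaPaCa cells, Homo sapiens) for inhibition, read by sulforhodamine B assay, with a stated time of 48 h (on this read-out higher numbers stand for weaker inhibition of growth and lower numbers for stronger inhibition of growth), compound 3 is known only through that limit, (the limit of > 100000 nM in this assay, at which 1 of the 3 values shown sits), so its place among the others is open. Compound 4 `O=C(CCN1C(=O)CSc2ccccc21)N1CCN(c2ccccc2F)CC1` differs from compound 3 by 2-fluorophenyl in place of 4-fluorophenyl on an amine nitrogen in a ring. The steps that change the group on the same amine nitrogen are an at least 1.4-fold higher number from compound 1 to compound 3 (0.16 log units; that floor lies within the scatter) and an at least 1.9-fold higher number from compound 2 to compound 3 (0.28 log units; that floor lies within the scatter), and the remaining step gave a 1.3-fold lower number from compound 1 to compound 2 (0.12 log units; within the scatter); none of these leaves the scatter. For this series no step beyond the scatter is expected from the present change. Compound 4 is therefore expected near that limit, estimated at 100000 nM with a range of 45000 nM to 220000 nM. The expected step is a number no higher from compound 3 to compound 4 (the limit leaves the size open).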

Compound 4, concentration for 50% growth inhibition: > 100000 nM
Compound 4: no number, only a limit; the forecaster's own chance of this, stated with the estimate: 55%; the middle value sits exactly at the limit.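

In this assay, the change from 4-fluorophenyl to 2-fluorophenyl brings no measurable growth inhibition into view: compound 3 and compound 4 are both known only through a limit of the assay, and the step between them cannot be read. Against the compounds with numbers, only floors can be read: an at least 1.9-fold higher number from compound 2 to compound 4 (0.28 log units; that floor lies within the scatter) and an at least 1.4-fold higher number from compound 1 to compound 4 (0.16 log units; that floor lies within the scatter). Both fluorophenyl compounds now sit at the same limit: the limit of > 100000 nM in this assay, at which 2 of the 4 values shown sit.

As far as these compounds go, whether the two fluorophenyl compounds differ beyond that limit stays open. Also open, from the compounds shown here alone, is how a benzyl group or a longer chain on the same amine nitrogen would read in this assay.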